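Trimethoxyphenyl enone series: third methoxy on the ketone aryl

The source may report more compounds than this note shows. Statements on the series, on what has been measured and on what is new or still open speak of the compounds shown alone.

Two compounds of the series have numbers in a functional assay on NCI-H522 cells (Homo sapiens) for inhibition, read by sulforhodamine B assay, with a stated time of 48 h; on this read-out higher numbers stand for weaker inhibition of growth and lower numbers for stronger inhibition of growth. Compound 1 `COc1cc(-c2cc(/C=C/C(=O)c3ccc(N)cc3)[nH]n2)cc(OC)c1OC` gives 3990 nM in this assay. Among the compounds with values here, compound 2 `COc1ccc(C(=O)/C=C/c2cc(-c3cc(OC)c(OC)c(OC)c3)n[nH]2)cc1OC` gives 390 nM in this assay, the lowest of the two numbers; the one measured step, a 10-fold lower number from compound 1 to compound 2 (1.01 log units; beyond the scatter), is large. Compound 3 `COc1cc(C(=O)/C=C/c2cc(-c3cc(OC)c(OC)c(OC)c3)n[nH]2)cc(OC)c1OC` is not yet measured. It differs from compound 2 by methoxy in place of hydrogen on an aromatic carbon, so that the aryl on the carbonyl carries three methoxy groups instead of two. Within the data shown here, no measured step bears directly on this change: the only step in hand exchanges the whole aryl on the carbonyl, and a third methoxy is a smaller alteration than that. A step of at most modest size is therefore expected in this assay, with no clear direction. Compound 3 is expected to give about 320 nM in this assay, within a range from 100 nM to 1000 nM. The expected step is a 1.2-fold lower number from compound 2 to compound 3 (0.09 log units; within the scatter), within the scatter.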

Compound 3, concentration for total growth inhibition: 1700 nM
Estimate against measurement, compound 3: 5.3-fold (0.73 log units) below; the measured number lies above the stated range.
By their numbers in this assay, from the lowest: compound 2; then compound 3; then compound 1.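

In this assay, the aryl on the carbonyl responds to a single added methoxy, not only to exchange of the whole aryl: a 4.4-fold higher number from compound 2 to compound 3 (0.64 log units; beyond the scatter). The earlier step, a 10-fold lower number from compound 1 to compound 2 (1.01 log units; beyond the scatter), favoured the 3,4-dimethoxyphenyl over the 4-aminophenyl, but the new step shows that further methoxy substitution on that aryl does not extend the gain and moves the number towards weaker inhibition of growth. Nothing in hand accounts for this shift.

As far as these compounds go, it remains open whether the shift belongs to methoxy specifically or would follow any group on this aromatic carbon. A fluorine or a hydroxyl there, or an ethoxy in its place, would test this, and the compounds shown give no guide to how any of these would read.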